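The source may report more compounds than this note shows. Statements on the series, on what has been measured and on what is new or still open speak of the compounds shown alone.

Working notes on the series. Compound 1 `CC#C[C@@H](CC(=O)O)c1ccc(OCc2cccc(-c3ccc(Cl)cc3C)c2)cc1` carries the shared core with an alkyne-bearing side chain; in a functional assay on A9 cells for agonist activity at Free fatty acid receptor 1 (Homo sapiens), read by inositol phosphate accumulation (on this read-out higher numbers stand for an effect only at larger amounts of compound and lower numbers for an effect already at smaller amounts), compound 1 gives "not determined" (no result reported), so no result is available for it. Going by the values given here, compound 2 `Cc1cc(Cl)ccc1-c1cccc(COc2ccc([C@H](CC(=O)O)c3nccn3C)cc2)c1` is the only member with a number in this assay: in this assay compound 2 gives 7.6 nM. Among the compounds with values here, no step between two measured compounds is available, so nothing sets the scale for a change at this position.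

Compound 3 `Cc1cc(Cl)ccc1-c1cccc(COc2ccc([C@H](CC(=O)O)c3ncnn3C)cc2)c1` is the next entry. It differs from compound 2 in one place: 1-methyl-1H-1,2,4-triazol-5-yl in place of 1-methyl-1H-imidazol-2-yl on a saturated chain carbon bound to an aromatic carbon and a saturated chain carbon. Both groups are the same size and neither carries a charge; the entering ring holds one more hetero atom. For this kind of exchange a small step is expected, in the direction of a later onset of effect, of roughly a 2.0-fold higher number from compound 2 to compound 3 (0.30 log units; within the scatter) for compound 3, which is close to the usual scatter. The estimate for compound 3 in this assay is 15 nM, with a range from 4 nM to 60 nM expected.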

Compound 3, half-maximal effective concentration: 11 nM
Estimate against measurement, compound 3: 1.4-fold (0.13 log units) above, and the stated range covers the measured number.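

In this assay the series now has its first readable step, and it sets a scale for this position: a 1.4-fold higher number from compound 2 to compound 3 (0.16 log units; within the scatter). On a saturated chain carbon bound to an aromatic carbon and a saturated chain carbon, 1-methyl-1H-1,2,4-triazol-5-yl and 1-methyl-1H-imidazol-2-yl therefore cannot be told apart on this read-out, even though the entering ring holds one more hetero atom and one more hydrogen-bond acceptor. No supporting measurement is at hand that could explain this result.

Compound 1 still has no number, so its alkyne-bearing side chain cannot be set against either ring. On these data alone, whether the same flat result would hold for a 1-methyl-1H-tetrazol-5-yl group, a phenyl ring or an imidazole without the methyl group remains open.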